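A few compounds are considered here, and "the series" means these few. Any claim that something is new, unique, unknown or untested is made for them only; others in the source may bear on it.

Compound 1 `CCn1c(=N)sc2cc(OC(F)(F)F)ccc21` is the parent of this small series. In a functional assay on the whole organism with Rattus norvegicus as the target (on this read-out higher numbers stand for an effect only at larger amounts of compound and lower numbers for an effect already at smaller amounts), compound 1 gives 5 mg/kg. Compound 2 `COC(=O)Cn1c(=N)sc2cc(OC(F)(F)F)ccc21` differs from it by an at least 2.0-fold higher number from compound 1 to compound 2 (0.30 log units; that floor lies within the scatter). In this assay compound 2 reaches only > 10 mg/kg, which is a limit of the assay and not a number. Compound 3 `N=c1sc2cc(OC(F)(F)F)ccc2n1CCS(=O)(=O)O` differs from compound 1 by an at least 2.0-fold higher number from compound 1 to compound 3 (0.30 log units; that floor lies within the scatter). In this assay compound 3 likewise stands at > 10 mg/kg, again a limit of the assay and not a number. Between these two the step that the two limits leave unreadable from compound 2 to compound 3 cannot be read. Compound 3 therefore sits at the limit of > 10 mg/kg in this assay, at which 2 of the 3 values shown sit, with no number of its own.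

Compound 4 `CSCCCn1c(=N)sc2cc(OC(F)(F)F)ccc21` has not yet been measured. It differs from compound 3 by (methylsulfanyl)methyl in place of sulfo on a saturated chain carbon, two bonds along the chain from an aromatic nitrogen. The measured steps that bear on this change are an at least 2.0-fold higher number from compound 1 to compound 2 (0.30 log units; that floor lies within the scatter) and an at least 2.0-fold higher number from compound 1 to compound 3 (0.30 log units; that floor lies within the scatter); both introduced a sulfo or methoxycarbonyl group onto the chain and both ended at the limit. The change to compound 4 removes the sulfo group and leaves a chain of carbon and sulfur, so compound 4 resembles compound 1 more closely than compound 3 does. Compound 4 is therefore expected to return to a readable number, with an at least 2.0-fold lower number from compound 3 to compound 4 (0.30 log units; that floor lies within the scatter) as the estimated step. The estimate for compound 4 is 5 mg/kg, with a range from 2 mg/kg to 12 mg/kg.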

Compound 4, dose for half-maximal effect: 4.2 mg/kg
Compound 4: the middle estimate sits 1.2-fold (0.08 log units) above what was measured, and the stated range covers the measured number.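

For the compounds shown here, until now every addition to this chain had ended at a limit of the assay, and compound 4 is the first compound with a substituted chain to give a readable value in this assay. With (methylsulfanyl)methyl on the saturated chain carbon, two bonds along the chain from an aromatic nitrogen, the result is a 1.2-fold lower number from compound 1 to compound 4 (0.08 log units; within the scatter), so a longer chain at this place leaves the read-out level with the parent. The same chain also gives an at least 2.3-fold lower number from compound 3 to compound 4 (0.37 log units; beyond the scatter) and an at least 2.3-fold lower number from compound 2 to compound 4 (0.37 log units; beyond the scatter), which ties the limit to the sulfo and methoxycarbonyl groups rather than to substitution of the chain as such, and the values at that end are limits of the assay, not numbers: the limit of > 10 mg/kg in this assay, at which 2 of the 4 values shown sit.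

The compounds shown leave open whether the sulfur in 3-(methylsulfanyl)propyl matters at all, or whether a plain butyl chain or an ether oxygen in its place would read the same. They also leave open how a carboxylic acid or an amine at the end of the chain would read, and how far the sulfo and methoxycarbonyl compounds lie past their limit.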